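Two Methoxy Groups Added to a Triazole Anti-inflammatory Series

The compounds below may be only part of what the source reports. "The series", "measured", "known", "first", "only" and "open" are said of these compounds alone.

Measured compounds:
compound 1, `COc1ccc(-c2nnc(SC/C(=N/O)c3ccccc3)n2-c2ccccc2)cc1`, 63%
compound 2, `COc1ccc(-c2nnc(SCC(=O)c3ccccc3)n2-c2ccccc2)cc1OC`, 59%
compound 3, `O/N=C(/CSc1nnc(-c2ccccc2)n1-c1ccccc1)c1ccccc1`, 65%

These three compounds were tested in a functional assay on the whole organism (strain albino) for inhibition, with Rattus norvegicus as the target, read by paw edema, with a stated time of 3 h, at a dose of 0.28 mmol/kg by the oral route; a lower number here means less inhibition, a higher number more inhibition at the dose given (going by the name of the read-out). Compound 3 shows the highest number of the three, yet its neighbours sit close: compound 1 is lower only by the step of a number 2 percentage points higher from compound 1 to compound 3 (within the scatter), and compound 2 lies a few points further down, both gaps being within the scatter. Compound 4, `COc1ccc(-c2nnc(SC/C(=N/O)c3ccccc3)n2-c2ccccc2)cc1OC`, is the next step: 3,4-dimethoxyphenyl in place of phenyl on an aromatic carbon. Going by the values given here, the one step that bears on it, a number 2 percentage points higher from compound 1 to compound 3 (within the scatter), moved the number by an amount inside the scatter, so no clear shift is expected. Compound 4 is therefore estimated to give 62%, within 50% to 73%, a step of a number 3 percentage points lower from compound 3 to compound 4 (within the scatter).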

Compound 4, a percentage reported as inhibition, in the whole organism at one dose (the size of the read-out at that dose, not a potency): 67%
Compound 4: the middle estimate sits 5 percentage points below what was measured; the range from low to high includes it.
By their numbers in this assay, from the lowest: compounds 2, 1, 3 and 4 (each within the scatter of the next).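

In this assay the change to 3,4-dimethoxyphenyl from phenyl on the shared core gives a number 2 percentage points higher from compound 3 to compound 4 (within the scatter) and adding one methoxy gives a number 4 percentage points higher from compound 1 to compound 4 (within the scatter), so this position takes the larger group without a shift beyond the usual scatter. Changing the group on the saturated chain carbon bound to a sulfur gives a number 8 percentage points higher from compound 2 to compound 4 (within the scatter), which is also no clear difference. Nothing measured here explains these numbers.

As far as these compounds go, whether a quite different group at this position, such as an amine or a carboxylic acid, would move the number remains open. So does how these compounds would compare at other doses.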